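Methylsulfanyl for Methylsulfonyl on a Chloro-Bearing Core

The compounds below may be only part of what the source reports. "The series", "measured", "known", "first", "only" and "open" are said of these compounds alone.

Measured compounds:
compound 1, `CS(=O)(=O)c1cc(F)ccc1NCC1=NCCN1`: 32%
compound 2, `CSc1cc(F)ccc1NCC1=NCCN1`: 82%
compound 3, `CS(=O)(=O)c1ccc(Cl)cc1NCC1=NCCN1`: 81%

In a functional assay on CHO cells for agonist activity at Alpha-2C adrenergic receptor (Homo sapiens) (a higher number here means a larger maximal response, a lower number a smaller maximal response), compound 1 gives 32%, whereas compound 2 gives 82%. The step of a number 50 percentage points higher from compound 1 to compound 2 (beyond the scatter) accompanies the change (methylsulfanyl in place of methylsulfonyl on an aromatic carbon). Compound 3 gives 81% in this assay, within the scatter of compound 2. The difference between the cores of compound 1 and compound 3 is not broken down here.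

Compound 4, `CSc1ccc(Cl)cc1NCC1=NCCN1`, arises from compound 3 by the same kind of change, (methylsulfanyl in place of methylsulfonyl on an aromatic carbon); the place differs in that it is para to a chloro group rather than meta to a fluoro group. For compound 4 a step of a number 7 percentage points higher from compound 3 to compound 4 (within the scatter) is expected, far smaller than the earlier one, because compound 3 already gives 81% and leaves little room above it. Compound 4 is therefore estimated at 88%, between 70% and 105%.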

Compound 4, largest response reached (reported as maximum), in percent of the reference or control that the assay uses: 92%
For compound 4 the middle estimate is 4 percentage points below the measured one; the measured number falls inside the stated range.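

In this assay, methylsulfanyl in place of methylsulfonyl again moves the maximal response in the same direction on the chloro-bearing core, with a number 11 percentage points higher from compound 3 to compound 4 (beyond the scatter). The direction of the change carries over between these two pairs, but its size does not: the same change on two cores in this assay, a number 50 percentage points higher (beyond the scatter) from compound 1 to compound 2 and a number 11 percentage points higher (beyond the scatter) from compound 3 to compound 4, 39 percentage points apart, beyond the scatter of two such steps

These two pairs do not show what in the cores sets the size of the step, nor whether the same direction would hold on any further core. The compounds shown leave open how a methylsulfinyl group, a methoxy group or an amine would compare in that same place. They also leave open whether the step would persist with a bromo group in place of the chloro group.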